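The compounds below may be only part of what the source reports. "The series", "measured", "known", "first", "only" and "open" are said of these compounds alone.

In an ADME assay on MDCK cells (Canis lupus familiaris) for cytotoxicity, read by microscopy, with a stated time of 48 h (a higher number here means that more compound is tolerated, a lower number that less compound is tolerated), compound 1 `CCCCc1csc(CN[C@@H]2C[C@H]3C[C@@H]([C@H]2C)C3(C)C)c1` gives 12500 nM. Compound 2 `C[C@H]1[C@H](NCc2cncnc2)C[C@H]2C[C@@H]1C2(C)C` reaches only a limit in this assay, > 100000 nM, which is the limit of > 100000 nM in this assay, at which 1 of the 2 values shown sits. Compound 3 `C[C@H]1[C@H](NCc2cccs2)C[C@H]2C[C@@H]1C2(C)C` differs from compound 2 in one place: thiophen-2-yl in place of pyrimidin-5-yl on a saturated chain carbon bound to an amine nitrogen. Within the data shown here, no measured pair shows this exchange by itself, so the size of the step can only be estimated. Compound 3 shares its thiophen-2-yl with compound 1, whose value sits lower; the step of an at least 2.0-fold lower number from compound 2 to compound 3 (0.30 log units; that floor lies within the scatter) is therefore expected to move toward that value without reaching it. Compound 3 is expected to give 50000 nM, somewhere from 12500 nM to 100000 nM.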

Compound 3, minimum cytotoxic concentration: 25000 nM
Estimate against measurement, compound 3: 2.0-fold (0.30 log units) above; the measured number falls inside the stated range.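

In this assay, thiophen-2-yl in place of pyrimidin-5-yl on a saturated chain carbon bound to an amine nitrogen gives an at least 4.0-fold lower number from compound 2 to compound 3 (0.60 log units; beyond the scatter), so this exchange alone lowers the tolerated concentration by more than the scatter. Compound 2 stands at a limit, not a number: the limit of > 100000 nM in this assay, at which 1 of the 3 values shown sits. Hydrogen in place of butyl on an aromatic carbon gives a 2.0-fold higher number from compound 1 to compound 3 (0.30 log units; within the scatter), so removing the butyl makes no change that can be told from the scatter. Still open, as far as these compounds go, is where a phenyl ring would fall at the same place, and whether a methyl or a longer chain on the thiophene would behave like butyl.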